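The compounds below may be only part of what the source reports. "The series", "measured", "known", "first", "only" and "open" are said of these compounds alone.

Compound 1 `C=C(Br)C(=O)Nc1ccc2oc(C(=O)NCCNC(=O)c3cc(OCC4(c5ccc(Cl)cc5)CC(=C)C(=O)O4)nn3C)cc2c1` is the reference point of this comparison. In a functional assay on K562 cells (Homo sapiens) for antiproliferative activity (on this read-out higher numbers stand for weaker inhibition and lower numbers for stronger inhibition), compound 1 gives 710 nM, the lowest of the two numbers obtained so far. The nearest measured neighbour, compound 3 `C=C(Br)C(=O)Nc1ccc2sc(C(=O)O)cc2c1`, gives 5000 nM in this assay, a higher number that lies beyond the usual scatter of repeated measurements. Compound 2 `C=C1CC(COc2cc(C(=O)O)n(C)n2)(c2ccc(Cl)cc2)OC1=O` reaches only a limit of the assay, reported as > 10000 nM in this assay, so no number is known for it; this is the situation described by the limit of > 10000 nM in this assay, at which 1 of the 3 values shown sits.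

The compound still to be tested is compound 4 `C=C(Br)C(=O)Nc1ccc2oc(C(=O)NCCNC(=O)c3cc(OCC4(c5ccc(-c6ccccc6)cc5)CC(=C)C(=O)O4)nn3C)cc2c1`. It differs from compound 1 in one place: phenyl in place of chloro on an aromatic carbon. No measured pair among the compounds shown carries this same change, so there is no step of known size to lean on. The expectation for compound 4 is therefore a step of modest size in this assay, in no firm direction, and likely within or only slightly beyond the scatter: the estimated step is a 1.3-fold higher number from compound 1 to compound 4 (0.10 log units; within the scatter). On that basis compound 4 is expected to give about 900 nM in this assay, with a plausible range from 300 nM to 3000 nM.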

Compound 4, half-maximal inhibitory concentration: 410 nM
For compound 4 the middle estimate is 2.2-fold (0.34 log units) above the measured one; measured number inside the range.
By their numbers in this assay, from the lowest: compounds 4 and 1 (each within the scatter of the next); then compound 3. At a limit, above all of these: compound 2.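

In this assay, the step of a 1.7-fold lower number from compound 1 to compound 4 (0.24 log units; within the scatter) shows that this place, on an aromatic carbon para to a large group, accepts phenyl in place of chloro with no change beyond the scatter. Six heavy atoms and a whole six-membered aromatic ring enter where a single chlorine leaves, yet compound 1 and compound 4 stay within the scatter of each other, something the earlier compounds, none of which carries a change at this place, could not show. Nothing in the data shown accounts for this step.

Going by these compounds, what an amine, a carboxylic acid or a methoxy group at this same place would give in this assay remains open. So does whether a longer chain in the linker would leave the step from 4-chlorophenyl to 4-phenylphenyl the same.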